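A few compounds are considered here, and "the series" means these few. Any claim that something is new, unique, unknown or untested is made for them only; others in the source may bear on it.

Measured compounds:
- compound 1 `COC(c1cc(Cl)c2c(c1Cl)C(=O)N(Cc1c(C)cc(C)[nH]c1=O)CC2)C1CCOCC1`; in an assay for inhibition of histone-lysine N-methyltransferase EZH2 variant Y641N (Homo sapiens), read by scintillation counting, with a stated time of 60 min, in the presence of a further agent that is not named here (a lower number here means a stronger inhibitor, a higher number a weaker inhibitor), compound 1 gives 310 nM; 0.1 nM (2 entries)
- compound 2 `Cc1cc(C)c(CN2CCc3c(Cl)cc([C@H](CO)[C@H]4CCCO4)c(Cl)c3C2=O)c(=O)[nH]1`; in this assay compound 2 gives 8 nM

Among the measured compounds shown here, compound 2 stands on the single number it shows; a further entry for it carries no single number. Compound 1 is not a clean anchor, since the several entries of compound 1 in this assay, 310 nM; 0.1 nM (2 entries) spread far apart. Compound 3 `Cc1cc(C)c(CN2CCc3c(Cl)cc([C@@H](CO)[C@@H]4CCCO4)c(Cl)c3C2=O)c(=O)[nH]1` differs from compound 2 in that (the two compounds have the same atoms and bonds and differ only in configuration as drawn: 2 of 2 stereo elements differ (all stereocentres are inverted: mirror images); a stereocentre at a saturated chain carbon is drawn R in compound 2 and S in compound 3; a stereocentre at a saturated ring carbon is drawn R in compound 2 and S in compound 3). For the measured compounds named here, no measured pair of mirror images is available here, so the size of the step rests on expectation only: an increase in the inhibition constant beyond the scatter is expected, with wide uncertainty. For compound 3 the estimate is 150 nM (range 10 nM to 3000 nM), an expected step of a 19-fold higher number from compound 2 to compound 3 (1.27 log units; beyond the scatter).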

Compound 3, inhibition constant: 135 nM
For compound 3 the middle estimate is 1.1-fold (0.05 log units) above the measured one, within the range that was stated.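

In this assay the configuration at this position clearly counts: with atoms and bonds unchanged, inverting both stereocentres gives a 17-fold higher number from compound 2 to compound 3 (1.23 log units; beyond the scatter). This mirror-image pair puts the first measured size on such a change, which compound 1 and compound 2 alone could not do. The step can be read as one of configuration alone: the fact that compounds 2 and 3 differ only in the configuration as drawn

Which of the two stereocentres carries the step stays open, as does what an amine or a carboxylic acid on that chain would do to the inhibition constant. Compound 1 offers no firm reference: the several entries of compound 1 in this assay, 310 nM; 0.1 nM (2 entries)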